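The compounds below may be only part of what the source reports. "The series", "measured", "known", "first", "only" and "open" are said of these compounds alone.

In an ADME assay on L6 cells (Rattus norvegicus) for cytotoxicity, read by fluorescence, with a stated time of 72 h (a lower number here means a stronger inhibitor, a higher number a weaker inhibitor), compound 1 (`CN1CCN(C23CC(NC(=O)CCN4CCCC4)C(C(c4ccccc4)C2)C(c2ccccc2)C3)CC1`) gives 42200 nM and compound 2 (`CCN(CC)CCC(=O)NC1CC2(N3CCN(C)CC3)CC(c3ccccc3)C1C(c1ccccc1)C2`) gives 35900 nM, so the two lie within the scatter of each other. Compound 3 (`CN1CCN(C23CC(NCCCN4CCCC4)C(C(c4ccccc4)C2)C(c2ccccc2)C3)CC1`) differs from compound 2 by 3-(pyrrolidin-1-yl)propyl in place of (2-(diethylamino)ethyl)carbonyl on an amine nitrogen. Among the compounds with values here, the one measured step, a 1.2-fold lower number from compound 1 to compound 2 (0.07 log units; within the scatter), exchanges only the pyrrolidin-1-yl and diethylamino ends. It suggests that this part of the change alone should move this assay little. Within the data shown here, no measured step covers the loss of the carbonyl, so that part of the change remains untested and the range has to stay wide. A moderate move towards a lower number is expected, with no firm support from the data, and the estimated step is a 2.4-fold lower number from compound 2 to compound 3 (0.38 log units; beyond the scatter). For compound 3 the expected value is 15000 nM, within an estimated range of 5000 nM to 42000 nM.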

Compound 3, half-maximal inhibitory concentration: 22600 nM
Compound 3: the middle estimate sits 1.5-fold (0.18 log units) below what was measured, and the stated range covers the measured number.
By their numbers in this assay, from the lowest: compounds 3, 2 and 1 (each within the scatter of the next).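

The exchange of (2-(pyrrolidin-1-yl)ethyl)carbonyl for 3-(pyrrolidin-1-yl)propyl on an amine nitrogen keeps the pyrrolidin-1-yl end and so isolates the loss of the carbonyl: in this assay it gives a 1.9-fold lower number from compound 1 to compound 3 (0.27 log units; within the scatter). The exchange that also replaces the diethylamino end gives a 1.6-fold lower number from compound 2 to compound 3 (0.20 log units; within the scatter), so at this position, across these three compounds, the carbonyl can be lost and the end group changed without a step beyond the scatter. No supporting data bear on why these numbers stay so close.

From the compounds shown here alone, it remains open whether a longer chain or a piperidin-1-yl end on this amine nitrogen would also stay within the scatter. Going by these compounds, a neutral end such as a hydroxyl group in place of the terminal amine is equally open.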